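This account rests on a few compounds, and the source may have more. Where it says the series, first, only, none or still open, it means among the compounds named here.

Measured compounds:

- compound 1, `COc1ccc(-c2cnc3nc(N)nc(N4CCN(C(=O)Nc5ccc(C)cc5)CC4)c3n2)cc1OC`: 0.8 nM
- compound 2, `CCOc1nc(N)nc2ncc(-c3cccc(OC)c3)nc12`: 8300 nM
- compound 3, `COc1ccc(-c2cnc3nc(N)nc(NCc4cccs4)c3n2)cc1OC`: 4100 nM

In a functional assay on cells (T-cell, Homo sapiens) for inhibition (a higher number here means a weaker inhibitor, a lower number a stronger inhibitor), compound 1 gives 0.8 nM, the lowest number of the three and therefore the strongest inhibitor in this set. The nearest to it is compound 3, which gives 4100 nM, a gap far beyond the usual scatter. Compound 2 gives 8300 nM, further away still. Both weaker compounds carry a different group where compound 1 carries its six-membered non-aromatic ring with 2 nitrogen and the (4-methylphenyl)carbamoyl on it, which suggests that this part of compound 1 matters, though neither differs from it in one place only.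

Compound 4, `COc1ccc(-c2cnc3nc(N)nc(N4CCN(Cc5c(Cl)cccc5Cl)CC4)c3n2)cc1OC`, keeps that ring and changes only what sits on its amine nitrogen: 2,6-dichlorobenzyl in place of (4-methylphenyl)carbamoyl on an amine nitrogen in a ring. Going by the values given here, no pair of measured compounds shows what this kind of swap does, so the expected direction rests on the pattern above. Compound 4 is expected to give 30 nM in this assay, with a range from 3 nM to 300 nM. That estimate means a step of a 38-fold higher number from compound 1 to compound 4 (1.57 log units; beyond the scatter) toward a weaker inhibitor, a step clearly beyond the scatter but smaller than the gaps to compound 2 and compound 3.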

Compound 4, half-maximal inhibitory concentration: 7600 nM
Compound 4: middle estimate off by 250-fold (2.40 log units), on the low side; measured number outside the range, above it.
By their numbers in this assay, from the lowest: compound 1; then compounds 3, 4 and 2 (each within the scatter of the next, the first and the last beyond it).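

In this assay keeping the six-membered non-aromatic ring with 2 nitrogen is not enough to keep a strong inhibitor: placing 2,6-dichlorobenzyl instead of (4-methylphenyl)carbamoyl on the amine nitrogen gives a 9500-fold higher number from compound 1 to compound 4 (3.98 log units; beyond the scatter) and so ties much of the strength of compound 1 to the group on that nitrogen. Both groups bring one six-membered aromatic ring of carbon only and have similar heavy-atom counts, yet only (4-methylphenyl)carbamoyl carries 1 hydrogen-bond donor, 1 hydrogen-bond acceptor and a double bond outside aromatic rings, so an aromatic ring on this nitrogen does not by itself give strong inhibition. Nothing available explains why this step is so large.

The swap changes the link to the aromatic ring and the groups on that ring together, so the compounds shown cannot tell which of these changes accounts for the loss. A 4-methylbenzyl or a (2,6-dichlorophenyl)carbamoyl on the same nitrogen would separate the two, since each would change only one of them relative to compound 1.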